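The source may report more compounds than this note shows. Statements on the series, on what has been measured and on what is new or still open speak of the compounds shown alone.

Of the compounds shown here, two have been tested so far in a functional assay on SGC-7901 cells (Homo sapiens) for antiproliferative activity, read by MTT assay, with a stated time of 72 h; on this read-out lower numbers stand for stronger inhibition and higher numbers for weaker inhibition. Within the data shown here, compound 2 `COc1ccc(-c2sc(C(=O)O)cc2-c2cc(OC)c(OC)c(OC)c2)cc1` gives 7800 nM, the only true number available in this small set. Compound 1 `CCOC(=O)c1cc(-c2cc(OC)c(OC)c(OC)c2)c(-c2cccc(Br)c2)s1` is reported as > 100000 nM, which is a limit of the assay and not a number. Compound 3 `COc1cc(-c2cc(C(=O)O)sc2-c2cccc(Br)c2)cc(OC)c1OC` has not yet been measured. It differs from compound 2 on an aromatic carbon of a five-membered aromatic ring with 1 sulfur, where 3-bromophenyl stands in place of 4-methoxyphenyl: 3-bromophenyl in place of 4-methoxyphenyl on an aromatic carbon. The carboxy group stays. Among the measured compounds shown here, no measured pair of compounds shows what such a swap does in this assay, so any forecast is uncertain. A modest loss of inhibition seems the most likely outcome, and the expected change is a 2.3-fold higher number from compound 2 to compound 3 (0.36 log units; beyond the scatter). For compound 3 the estimated value is 18000 nM, with an expected range of 4000 nM to 80000 nM.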

Compound 3, half-maximal inhibitory concentration: 93400 nM
Compound 3: middle estimate off by 5.2-fold (0.72 log units), on the low side; the whole stated range lies below it.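

In this assay, putting 3-bromophenyl in place of 4-methoxyphenyl on the aromatic carbon next to the ring sulfur, with the carboxy group kept, gives a 12-fold higher number from compound 2 to compound 3 (1.08 log units; beyond the scatter), a large loss of inhibition. Among these compounds, this is the first single-place comparison in the set, and it shows that inhibition at this position depends strongly on which aryl group is attached. Hydrogen in place of ethyl on an oxygen next to a carbonyl group gives an at least 1.0-fold lower number from compound 1 to compound 3 (0.02 log units; that floor lies within the scatter). This step gives only a floor, because compound 1 is reported only as a limit and not as a number: the limit of > 100000 nM in this assay, at which 1 of the 3 values shown sits.

The compounds shown leave open whether the loss follows from the departure of the methoxy group, the arrival of the bromine, or both. They also leave open whether a phenyl ring carrying a hydroxyl or an amine at this position would retain the inhibition seen with compound 2.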